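Notes on the step from compound 3 to compound 4

A few compounds are considered here, and "the series" means these few. Any claim that something is new, unique, unknown or untested is made for them only; others in the source may bear on it.

Three compounds have numbers in a functional assay on K562 cells (Homo sapiens) for cytotoxicity, read by MTT assay, with a stated time of 72 h; a higher number here means a weaker inhibitor of growth, a lower number a stronger inhibitor of growth. Compound 1 `O=C(/N=C(/NC(=O)c1ccco1)[Se]Cc1ccccc1)c1ccco1` gives 9530 nM. Compound 2 `C[Se]/C(=N\C(=O)c1cnc2ccccc2c1)NC(=O)c1cnc2ccccc2c1` gives 3800 nM, and compound 3 `CS/C(=N\C(=O)c1cnc2ccccc2c1)NC(=O)c1cnc2ccccc2c1` gives 65800 nM. Compound 3 thus stands highest of the three: compound 1 lies nearest to it and compound 2 furthest, both gaps beyond the scatter. For the measured compounds named here, the only single-place step among the measured compounds is a 17-fold higher number from compound 2 to compound 3 (1.24 log units; beyond the scatter), a large one.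

Compound 4 `O=C(/N=C(/NC(=O)c1cnc2ccccc2c1)[Se]Cc1ccccc1)c1cnc2ccccc2c1` is not yet measured. It differs from compound 3 by a group of 8 heavy atoms (7 carbon, 1 selenium; one six-membered aromatic ring of carbon only) in place of a group of 2 heavy atoms (1 carbon, 1 sulfur; no ring), on a carbon with a double bond to nitrogen. This reverses the exchange seen in the measured step and also enlarges the group on that carbon. The step from compound 2 to compound 3 bears directly on it; its reverse would by itself give a large lowering. Compound 1, carrying the same entering group on another core, gives a number in the same region as compound 2, though the two differ in more than one place.

Compound 4 is therefore expected to show a large drop, a 16-fold lower number from compound 3 to compound 4 (1.22 log units; beyond the scatter), in this assay. The estimate for compound 4 is 4000 nM, with a range from 1500 nM to 12000 nM.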

Compound 4, concentration for 50% growth inhibition: 29300 nM
Beside the measured number, compound 4's estimate is 7.3-fold (0.86 log units) below it; measured number outside the range, above it.
By their numbers in this assay, from the lowest: compound 2; then compound 1; then compound 4; then compound 3.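

In this assay, phenyl in place of hydrogen on the saturated chain carbon bound to selenium gives a 7.7-fold higher number from compound 2 to compound 4 (0.89 log units; beyond the scatter), so with selenium kept in place, enlarging the group on the carbon with a double bond to nitrogen costs activity. Compound 4 still improves on the sulfur compound, but only by a 2.2-fold lower number from compound 3 to compound 4 (0.35 log units; beyond the scatter), far less than the difference seen in a 17-fold higher number from compound 2 to compound 3 (1.24 log units; beyond the scatter), so the selenium exchange alone does not set the number at this position. No supporting measurement bears on these steps.

The compounds shown leave open how the number changes with chain size on selenium, for example with an ethyl chain, or with an amine carried on that chain. They also leave open whether the phenyl effect holds when sulfur replaces selenium.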